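A Methyl Step Across Two Closely Related Cores

This account rests on a few compounds, and the source may have more. Where it says the series, first, only, none or still open, it means among the compounds named here.

Four compounds are compared here, built on a shared core that holds two aryl rings and a short alkyl chain. Compound 1 `COc1ccc(-c2noc(-c3ccc(OC)cc3)c2C)cc1` and compound 2 `CCc1c(-c2ccc(OC)cc2)noc1-c1ccc(OC)cc1` form one pair; compound 2 arises from compound 1 through (methyl in place of hydrogen on a saturated chain carbon bound to an aromatic carbon). Compound 3 `Cc1c(-c2ccc(O)cc2)noc1-c1ccc(O)cc1` and compound 4 `CCc1c(-c2ccc(O)cc2)noc1-c1ccc(O)cc1` form the second pair, and compound 4 arises from compound 3 through (methyl in place of hydrogen on a saturated chain carbon bound to an aromatic carbon). The difference between the core of compound 1 and the core of compound 3 is not broken down here. Since the place of the change is the same word for word in both pairs, the two steps can be called the same change.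

In a functional assay on MCF7 cells (Homo sapiens) for antiproliferative activity, read by cell counting, with a stated time of 5 days (on this read-out lower numbers stand for stronger inhibition and higher numbers for weaker inhibition), compound 1 reaches only the limit of the assay, > 100000 nM. Compound 2 likewise gives only a limit in this assay, > 100000 nM. The step between them, a step that the two limits leave unreadable from compound 1 to compound 2, therefore cannot be sized, because of the limit of > 100000 nM in this assay, at which 2 of the 3 values shown sit. Within the data shown here, compound 3 is the one compound with a number in this assay, giving 48000 nM.

Compound 4 has not yet been measured in this assay. The earlier step gives no readable size, so the expectation rests on compound 3 alone with its 48000 nM. The step is expected to be small, a 1.1-fold lower number from compound 3 to compound 4 (0.03 log units; within the scatter). Compound 4 is estimated at 45000 nM, likely between 15000 nM and 100000 nM.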

Compound 4, half-maximal inhibitory concentration: 9800 nM
The estimate for compound 4 lay 4.6-fold (0.66 log units) above the measured number; the measured number lies below the stated range.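

In this assay, the change from methyl to ethyl has a readable size on the core of compound 3, a 4.9-fold lower number from compound 3 to compound 4 (0.69 log units; beyond the scatter), so on this core the longer chain goes with stronger inhibition of cell growth. The same change on the core of compound 1 offers no size to set beside it, because the step there runs between two limits of the assay rather than two numbers: the limit of > 100000 nM in this assay, at which 2 of the 4 values shown sit.

From the compounds shown here alone, this leaves a single readable step, which shows what the change does on one core but neither confirms nor rules out that it carries over to the other, and whether compound 2 is truly stronger or weaker than compound 1 remains unknown.

The compounds shown leave open whether a propyl chain in place of the ethyl of compound 4 would lower the number again, raise it or leave it unchanged. They also leave open how a chain ending in an amine or a carboxylic acid would behave on the core of compound 3, and a second core with readable numbers would be needed to test whether the step repeats.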